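Moving atoms within one group on the carbonyl carbon

The compounds below may be only part of what the source reports. "The series", "measured", "known", "first", "only" and "open" are said of these compounds alone.

In a physicochemical assay for solubility, in phosphate buffer, with a stated time of 24 h, at pH 7.4, tested at 100 uM (on this read-out lower numbers stand for lower solubility and higher numbers for higher solubility), compound 3 (`O=C(NCc1ccc(S(=O)(=O)c2ccccc2)cc1)N1Cc2ccncc2C1`) reads 115000 nM and stands highest of the three measured, ahead of compound 1 (`O=C(NCc1ccc(S(=O)(=O)c2ccccc2)cc1)NCc1cccnc1`) at 10000 nM and compound 2 (`O=C(NCc1ccc(S(=O)(=O)c2ccccc2)cc1)c1cc2cnccc2[nH]1`) at 3000 nM in this series. The change to compound 4 (`O=C(NCc1ccc(S(=O)(=O)c2ccccc2)cc1)N1Cc2cccnc2C1`) is a group of 9 heavy atoms (7 carbon, 2 nitrogen; one five-membered non-aromatic ring with 1 hetero atom, one six-membered aromatic ring with 1 hetero atom) in place of a group of 9 heavy atoms (7 carbon, 2 nitrogen; one five-membered non-aromatic ring with 1 hetero atom, one six-membered aromatic ring with 1 hetero atom), on a carbonyl carbon and keeps the same atoms, joined differently. Changes at this carbonyl carbon have shifted the numbers before: the measured steps show a 12-fold higher number from compound 1 to compound 3 (1.06 log units; beyond the scatter) and a 38-fold higher number from compound 2 to compound 3 (1.58 log units; beyond the scatter) as large changes and a 3.3-fold lower number from compound 1 to compound 2 (0.52 log units; beyond the scatter) as a modest one. None of them joins two groups with the same atoms and the same ring types. A modest fall is therefore expected, an estimated 2.3-fold lower number from compound 3 to compound 4 (0.36 log units; beyond the scatter) in this assay with wide uncertainty. For compound 4 the estimated value is 50000 nM within an expected range from 12000 nM to 130000 nM in this measurement.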

Compound 4, solubility: 144000 nM
Estimate against measurement, compound 4: 2.9-fold (0.46 log units) below, outside the stated range (above it).
By their numbers in this assay, from the lowest: compound 2; then compound 1; then compounds 3 and 4 (each within the scatter of the next).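

In this assay, rearranging the atoms within the group on the carbonyl carbon gives a 1.3-fold higher number from compound 3 to compound 4 (0.10 log units; within the scatter), so at this position the two groups read alike. The large gap first seen with compound 3 also holds for its isomer, with a 14-fold higher number from compound 1 to compound 4 (1.16 log units; beyond the scatter) and a 48-fold higher number from compound 2 to compound 4 (1.68 log units; beyond the scatter). No supporting measurement accounts for this result. The compounds shown leave open whether a morpholine or a piperazine on the same carbonyl carbon would read like compound 3 and compound 4 or fall nearer compound 1 and compound 2.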